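A Methyl on the Anilino Ring: Compound 3 to Compound 4

The compounds below may be only part of what the source reports. "The series", "measured", "known", "first", "only" and "open" are said of these compounds alone.

Measured so far:
Compound 1 `NC(=O)c1c(NC(=O)c2ccccc2Cl)sc2c1CCN(Cc1ccc(Cl)cc1Cl)C2` gives 21100 nM in a functional assay on HeLa cells (Homo sapiens) for antiproliferative activity, with a stated time of 24 h; a higher number here means a weaker inhibitor, a lower number a stronger inhibitor.
Compound 2 `NC(=O)c1c(NC(=O)c2ccccc2Cl)sc2c1CCN(Cc1cc(Cl)cc(Cl)c1)C2` gives 19600 nM in this assay.
Compound 3 `NC(=O)c1c(NC(=O)c2ccccc2Cl)sc2c1CCN(C(=S)Nc1ccccc1)C2` gives 46700 nM in this assay.

Compound 3 carries the highest number of the three: a 2.2-fold higher number from compound 1 to compound 3 (0.35 log units; beyond the scatter) and a 2.4-fold higher number from compound 2 to compound 3 (0.38 log units; beyond the scatter), both modest but beyond the scatter, whereas a 1.1-fold lower number from compound 1 to compound 2 (0.03 log units; within the scatter) stays within it. Compound 4 `Cc1ccccc1NC(=S)N1CCc2c(sc(NC(=O)c3ccccc3Cl)c2C(N)=O)C1` differs from compound 3 by methyl in place of hydrogen on an aromatic carbon. Among the measured compounds shown here, no measured pair shows what such a methyl does here; the measured steps swap the whole group on the ring nitrogen, never a single aromatic hydrogen. With nothing pointing either way, no change beyond the scatter is expected, so compound 4 is estimated at 45000 nM, within a range from 18000 nM to 110000 nM. That corresponds to an expected step of a 1.0-fold lower number from compound 3 to compound 4 (0.02 log units; within the scatter).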

Compound 4, half-maximal inhibitory concentration: > 50000 nM
Compound 4 gave a limit, no number; the forecaster's own chance of this, stated with the estimate: 10%; middle value at least 1.1-fold (0.04 log units) from the limit.
By their numbers in this assay, from the lowest: compounds 2 and 1 (each within the scatter of the next); then compound 3. At a limit, above all of these: compound 4.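

Compound 4 stands at a limit, not a number: the limit of > 50000 nM in this assay, at which 1 of the 4 values shown sits. The methyl, ortho to a large group, gives an at least 1.0-fold higher number from compound 3 to compound 4 (0.02 log units; that floor lies within the scatter), so this first single-hydrogen change cannot show whether the methyl alters activity. The gap to the benzyl-type compounds can be read: an at least 2.5-fold higher number from compound 2 to compound 4 (0.40 log units; beyond the scatter), and an at least 2.3-fold higher number from compound 1 to compound 4 (0.37 log units; beyond the scatter), though both steps swap the whole group on the ring nitrogen.

Going by these compounds, how far the true value of compound 4 lies past its limit stays open. So does whether an amine or a hydroxyl group in place of this methyl would give a lower number.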